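Meta-methoxy aniline on a shared aminocycloheptapyrimidine core

The source may report more compounds than this note shows. Statements on the series, on what has been measured and on what is new or still open speak of the compounds shown alone.

Compound 1 `N[C@H]1CCc2nc(-c3ccncc3)nc(Nc3cccc(F)c3)c2C1` and compound 2 `CN(C)c1ccc(Nc2nc(-c3ccncc3)nc3c2CC(N)CC3)cc1` share one core and differ in the aniline attached to it. In a functional assay on A-375 cells (Homo sapiens) for antiproliferative activity, read by MTT assay, with a stated time of 72 h (a higher number here means a weaker inhibitor, a lower number a stronger inhibitor), compound 1 gives 10700 nM, and compound 2 gives 12600 nM; the two numbers lie within the scatter of each other, so neither stands apart. Compound 3 `COc1cccc(Nc2nc(-c3ccncc3)nc3c2CC(N)CC3)c1` carries 3-methoxyphenyl in place of 4-(dimethylamino)phenyl on a nitrogen on an aromatic ring. Among the measured compounds shown here, with no step between measured compounds to lean on, the change is expected to move this assay little, if at all, beyond the scatter. For compound 3 the estimate is 10000 nM, in the range 4000 nM to 30000 nM, an expected step of a 1.3-fold lower number from compound 2 to compound 3 (0.10 log units; within the scatter).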

Compound 3, half-maximal inhibitory concentration in the A-375 assay: 15100 nM
Estimate against measurement, compound 3: 1.5-fold (0.18 log units) below; measured number inside the range.
By their numbers in the A-375 assay, from the lowest: compounds 1, 2 and 3 (each within the scatter of the next).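

In the A-375 assay, the replacement of 4-(dimethylamino)phenyl by 3-methoxyphenyl on a nitrogen on an aromatic ring gives a 1.2-fold higher number from compound 2 to compound 3 (0.08 log units; within the scatter), so this place took the change without a step beyond the scatter. In a physicochemical assay for solubility, read by HPLC, in phosphate buffer, measured as kinetic solubility, with a stated time of 24 h, at pH 7.4 (a lower number here means a less soluble compound, a higher number a more soluble compound), compound 2 gives > 250000 nM, which is a limit of the assay. In the physicochemical assay compound 3 gives > 250000 nM, also a limit, so no step between the two compounds can be read: the limit of > 250000 nM in the physicochemical assay, at which 2 of the 2 values shown sit.

Still open, from the compounds shown here alone, is whether a carboxylic acid or an amine on a longer chain at this place would move the A-375 assay beyond the scatter.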